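This account rests on a few compounds, and the source may have more. Where it says the series, first, only, none or still open, it means among the compounds named here.

Measured so far in a physicochemical assay for lipophilicity, using the shake flask method, in phosphate buffer, measured as octanol-water partition, with a stated time of 85 min, at pH 7.4; a lower number here means a more polar compound, a higher number a more lipophilic compound:
Compound 1, `c1ccc(-c2cn3ccnc3c(-c3ccc4ncn(C5CCCCC5)c4c3)n2)cc1`, gives 1.74
Compound 2, `COc1ccc(-c2cn3ccnc3c(-c3ccc4ncn(C5CCCCC5)c4c3)n2)cc1`, gives 1.41
Compound 3, `CC(=O)c1ccc(-c2cn3ccnc3c(-c3ccc4ncn(C5CCCCC5)c4c3)n2)cc1`, gives 2.06

Among these three, compound 3 stands highest: it lies a number 0.32 log units higher from compound 1 to compound 3 (beyond the scatter) and a number 0.65 log units higher from compound 2 to compound 3 (beyond the scatter), both beyond the scatter, while compound 2 sits lowest with a number 0.33 log units lower from compound 1 to compound 2 (beyond the scatter). The next compound, compound 4, is `Brc1ccc(-c2cn3ccnc3c(-c3ccc4ncn(C5CCCCC5)c4c3)n2)cc1`. Its difference from compound 3 is bromo in place of acetyl on an aromatic carbon: the acetyl leaves and a bromo enters, on the aromatic carbon para to a large group.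

For the measured compounds named here, no measured step exchanges an acetyl for a bromo, so only indirect guidance is available. The two steps that end at compound 3 show that the acetyl raised this assay modestly relative to hydrogen and to methoxy. Taking the bromo to lie on the higher side of that series, the expected step is a number 0.34 log units higher from compound 3 to compound 4 (beyond the scatter), a modest rise. Compound 4 is therefore estimated at 2.4, with a range from 1.9 to 2.9.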

Compound 4, partition coefficient: 1.73
Compound 4: the middle estimate sits 0.67 log units above what was measured, and the stated range ends above it.
By their numbers in this assay, from the lowest: compound 2; then compounds 4 and 1 (each within the scatter of the next); then compound 3.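

In this assay, for the compounds shown here, a bromo on this aromatic carbon, para to a large group, shows something the earlier compounds could not: the swap for hydrogen gives a number 0.01 log units lower from compound 1 to compound 4 (within the scatter) and so cannot be told apart from no substituent at all. The other two comparisons place bromo on opposite sides, with a number 0.33 log units lower from compound 3 to compound 4 (beyond the scatter) and a number 0.32 log units higher from compound 2 to compound 4 (beyond the scatter) in this series, so here bromo and hydrogen stand together between acetyl and methoxy. Nothing measured here accounts for these differences.

Going by these compounds, whether an amine, a carboxylic acid or a longer chain on this same carbon would fall inside or outside the span set by methoxy and acetyl stays open. So does whether these groups would keep the same order at any other place on the shared core.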